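Benzyl in Place of Phenyl and Cytotoxicity

The compounds below may be only part of what the source reports. "The series", "measured", "known", "first", "only" and "open" are said of these compounds alone.

Compound 1 `O=C(NCc1ccccc1)Oc1ccc(Cl)cc1C(=O)Nc1ccc(F)cc1`, compound 2 `O=C(Nc1ccccc1)Oc1ccc(Cl)cc1C(=O)Nc1ccc(F)cc1` and compound 3 `O=C(Nc1ccccc1)Oc1ccccc1C(=O)Nc1ccccc1` have been tested in an ADME assay on HepG2 cells (Homo sapiens) for cytotoxicity, read by MTT assay (on this read-out lower numbers stand for stronger inhibition and higher numbers for weaker inhibition), while compound 4 `O=C(NCc1ccccc1)Oc1ccccc1C(=O)Nc1ccccc1` has not yet been measured. In this assay compound 1 gives > 125000 nM, a limit of the assay rather than a number. Compound 2 also gives only a limit, > 20000 nM. Among the compounds with values here, compound 3 gives 57700 nM, the one plain number among the three. The difference between the cores of compound 2 and compound 3 is not broken down here. From compound 2 to compound 1 the change is benzyl in place of phenyl on an amide-type nitrogen, and the step that the two limits leave unreadable from compound 2 to compound 1 stays unreadable since both ends rest on limits. The same change, (benzyl in place of phenyl on an amide-type nitrogen), leads from compound 3 to compound 4. With no readable measured step, the expected step of a 1.2-fold higher number from compound 3 to compound 4 (0.08 log units; within the scatter) rests only on compound 3 at 57700 nM and is estimated as small. Compound 4 is therefore expected at 70000 nM, between 25000 nM and 200000 nM.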

Compound 4, half-maximal inhibitory concentration: > 125000 nM
Compound 4: only a limit was reported (the forecaster's own chance of this, stated with the estimate: 40%); middle value at least 1.7-fold (0.25 log units) away from the limit.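

In this assay, putting benzyl in place of phenyl on an amide-type nitrogen gives an at least 2.1-fold higher number from compound 3 to compound 4 (0.33 log units; beyond the scatter), so on the core of compound 3 the change weakens the read-out beyond the scatter. Compound 4 gives > 125000 nM, which is a limit of the assay and not a number: the limit of > 125000 nM in this assay, at which 2 of the 4 values shown sit. Within the data shown here, the step from compound 2 to compound 1 cannot be read, so this is the only readable step, and it does not show whether the change carries over with a similar size from one core to the other.

As far as these compounds go, it remains open how a longer chain such as phenethyl, or a benzyl bearing an amine or a carboxylic acid, would read on this nitrogen.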